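The compounds below may be only part of what the source reports. "The series", "measured", "known", "first", "only" and "open" are said of these compounds alone.

Measured so far:
compound 1 `Cc1nc(S(C)(=O)=O)ccc1Oc1ncnc(OC2CCN(C(=O)OC3(C(F)(F)F)CCC3)CC2)c1F` — 82%
compound 2 `Cc1nc(S(C)(=O)=O)ccc1Oc1ncnc(OC2CCN(C(=O)C(C)(F)F)CC2)c1F` — 87%

In a functional assay on isolated protein for inhibition of Glucose-dependent insulinotropic receptor (Rattus norvegicus), read by HTRF and cAMP accumulation (a higher number here means a larger maximal response, a lower number a smaller maximal response), compound 1 gives 82% and compound 2 gives 87%. Compound 2 holds the larger of the two numbers, but the step of a number 5 percentage points higher from compound 1 to compound 2 (within the scatter) is within the scatter, so the two stand level. Compound 3 `Cc1nc(S(C)(=O)=O)ccc1Oc1ncnc(OC2CCN(C(=O)c3nc(C(C)(C)F)no3)CC2)c1F` differs from compound 2 by a group of 9 heavy atoms (5 carbon, 2 nitrogen, 1 oxygen, 1 fluorine; one five-membered aromatic ring with 3 hetero atoms) in place of a group of 4 heavy atoms (2 carbon, 2 fluorine; no ring), on a carbonyl carbon. For the measured compounds named here, the one measured step bearing on this change also swapped the group on the same carbonyl carbon, and it moved the maximal response only within the scatter. For compound 3 the step of a number 2 percentage points lower from compound 2 to compound 3 (within the scatter) is therefore expected to stay within the scatter. Compound 3 is estimated at 85%, range 72% to 98%.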

Compound 3, largest response reached (reported as efficacy), in percent of the reference or control that the assay uses: 84%
The estimate for compound 3 lay 1 percentage points above the measured number; measured number inside the range.
By their numbers in this assay, from the lowest: compounds 1, 3 and 2 (each within the scatter of the next).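

In this assay, a five-membered aromatic ring with 3 hetero atoms on the carbonyl carbon stands level with 1,1-difluoroethyl (a number 3 percentage points lower from compound 2 to compound 3 (within the scatter)). It also stands level with the carbamate-linked four-membered carbon ring group of compound 1 (a number 2 percentage points higher from compound 1 to compound 3 (within the scatter)), so an aromatic ring at this place leaves the maximal response within the scatter of both non-aromatic groups. No supporting data explain this level response. Open, from the compounds shown here alone, is whether an amine or a carboxylic acid on this carbonyl carbon would move the maximal response beyond the scatter.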